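The compounds below may be only part of what the source reports. "The series", "measured", "known", "first", "only" and "open" are said of these compounds alone.

Working notes on the series. The compounds share one core and differ in the aryl group on a carbon with a double bond to nitrogen. In a functional assay on A549 cells (Homo sapiens) for cytotoxicity, read by MTT assay, with a stated time of 72 h (a higher number here means a weaker inhibitor, a lower number a stronger inhibitor), compound 2 `CN(C)CCn1cnnc1-c1cc(Oc2ccc(NC(=O)N/N=C/c3ccc(F)cc3F)cc2F)ccn1` gives 1870 nM. Compound 1 `CN(C)CCn1cnnc1-c1cc(Oc2ccc(NC(=O)N/N=C/c3cc(C(C)(C)C)cc(C(C)(C)C)c3O)cc2F)ccn1` gives 980 nM in this assay, within the scatter of compound 2. Compound 3 `COc1cc(/C=N/NC(=O)Nc2ccc(Oc3ccnc(-c4nncn4CCN(C)C)c3)c(F)c2)cc(OC)c1OC` gives > 100000 nM in this assay, which is a limit of the assay and not a number (the limit of > 100000 nM in this assay, at which 1 of the 3 values shown sits). For the measured compounds named here, the only measured step, an at least 53-fold higher number from compound 2 to compound 3 (1.72 log units; beyond the scatter), exchanges the whole 2,4-difluorophenyl for 3,4,5-trimethoxyphenyl. Compound 4 `CN(C)CCn1cnnc1-c1cc(Oc2ccc(NC(=O)N/N=C/c3ccc(F)cc3Cl)cc2F)ccn1` differs from compound 2 by chloro in place of fluoro on an aromatic carbon. That change is far smaller than the measured one, so no step beyond the scatter is expected in this assay. Compound 4 is estimated at 1600 nM (range 600 nM to 4500 nM), the expected step being a 1.2-fold lower number from compound 2 to compound 4 (0.07 log units; within the scatter).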

Compound 4, half-maximal inhibitory concentration: 1120 nM
Beside the measured number, compound 4's estimate is 1.4-fold (0.15 log units) above it; the range from low to high includes it.
By their numbers in this assay, from the lowest: compounds 1, 4 and 2 (each within the scatter of the next). At a limit, above all of these: compound 3.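

In this assay, chloro in place of fluoro on this aromatic carbon, ortho to a large group, stays within the scatter: a 1.7-fold lower number from compound 2 to compound 4 (0.22 log units; within the scatter). The large gap to the 3,4,5-trimethoxyphenyl compound therefore holds for the 2-chloro-4-fluorophenyl group too: an at least 89-fold lower number from compound 3 to compound 4 (1.95 log units; beyond the scatter). That step rests on the value of compound 3, which is a limit of the assay and not a number: the limit of > 100000 nM in this assay, at which 1 of the 4 values shown sits.

From the compounds shown here alone, what an amine or a carboxylic acid on this aromatic carbon would give remains open. Also open, going by these compounds, is which methoxy groups of compound 3 go with its large step.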